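This account rests on a few compounds, and the source may have more. Where it says the series, first, only, none or still open, it means among the compounds named here.

Measured compounds:
compound 1 `Cc1cccc(NC(=O)CCN2CCN(c3ccccn3)CC2)c1` gives 1090 nM
compound 2 `Cc1cccc(NC(=O)CN2CCN(c3ccc(Cl)cn3)CC2)c1` gives 7780 nM

Both numbers come from an assay on cells for antagonist activity at D(4) dopamine receptor (Homo sapiens), read by luminescence and beta-arrestin recruitment, with a stated time of 90 min; on this read-out lower numbers stand for stronger inhibition and higher numbers for weaker inhibition. Of the two, compound 1 holds the lower number; compound 2, which differs from it in more than one place, lies at a higher number, and the gap between them is beyond the usual scatter. Nothing further can be drawn from that pair, since they are not a single-point step.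

The step under consideration leads from compound 1 to compound 3 `Cc1cccc(NC(=O)CCN2CCN(c3ncccn3)CC2)c1`. The change is pyrimidin-2-yl in place of pyridin-2-yl on an amine nitrogen in a ring; the rest of the core of compound 1 is kept. Among the measured compounds shown here, no single-point step between measured compounds is available to calibrate it, so the expectation rests on compound 1 alone. In this assay the step from compound 1 to compound 3 is expected to be small, a 1.5-fold higher number from compound 1 to compound 3 (0.17 log units; within the scatter), most likely no larger than the scatter and, if anything, toward a slightly higher number. Compound 3 is therefore estimated at 1600 nM in this assay, with a range from 500 nM to 5000 nM.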

Compound 3, half-maximal inhibitory concentration: 430 nM
The estimate for compound 3 lay 3.7-fold (0.57 log units) above the measured number; the measured number lies below the stated range.
By their numbers in this assay, from the lowest: compound 3; then compound 1; then compound 2.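

Read in this assay, the exchange of pyridin-2-yl for pyrimidin-2-yl on the amine nitrogen gives a 2.5-fold lower number from compound 1 to compound 3 (0.40 log units; beyond the scatter), the first single-point step in this series, and it shows that this position responds to a modest change in the ring it carries. The group keeps its six-membered aromatic ring and its heavy-atom count, and only one carbon gives way to a nitrogen, yet that is enough to move the number beyond the scatter, toward stronger inhibition. Nothing at hand explains why the number moves in this direction.

Going by these compounds, it remains open whether a pyrazin-2-yl or a pyridin-3-yl group on the same amine nitrogen would move the number further in this direction or take it back. On these data alone, since this is a single step on one core, it is also open whether pyrimidin-2-yl would bring a step of similar size if the methyl group on the other aromatic ring were replaced by a chlorine atom.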